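A few compounds are considered here, and "the series" means these few. Any claim that something is new, unique, unknown or untested is made for them only; others in the source may bear on it.

Compound 1 `COc1ccc2c(=O)c(/C=C/C(=O)Nc3ccc(C)cc3)coc2c1`, compound 2 `COc1ccc2c(=O)c(/C=C/C(=O)Nc3ccccc3OC)coc2c1` and compound 3 `COc1ccc(NC(=O)/C=C/c2coc3cc(OC)ccc3c2=O)cc1` share one core and differ in the group on the amide-type nitrogen. In a functional assay on Huh-7 cells (Homo sapiens) for inhibition, read by MTT assay, with a stated time of 48 h (a lower number here means a stronger inhibitor, a higher number a weaker inhibitor), compound 2 gives 32300 nM. Compound 1 reaches only the limit of this assay, > 100000 nM. Compound 3 likewise stands at a limit, > 100000 nM, so its place is known only as a bound. Both limits fall under (the limit of > 100000 nM in this assay, at which 2 of the 3 values shown sit). The readable steps are an at least 3.0-fold lower number from compound 1 to compound 2 (0.49 log units; beyond the scatter) and an at least 3.0-fold higher number from compound 2 to compound 3 (0.49 log units; beyond the scatter), while a step that the two limits leave unreadable from compound 1 to compound 3. Compound 4 `COc1ccc2c(=O)c(/C=C/C(=O)NCc3ccc(F)cc3F)coc2c1` is unmeasured and carries 2,4-difluorobenzyl in place of 4-methoxyphenyl on an amide-type nitrogen. Among the measured compounds shown here, no measured step covers a 2,4-difluorobenzyl group, so the estimated step of an at least 1.2-fold lower number from compound 3 to compound 4 (0.09 log units; that floor lies within the scatter) is taken as no move beyond the scatter. Compound 4 is therefore expected to give about 80000 nM in this assay, within 20000 nM to 300000 nM.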

Compound 4, half-maximal inhibitory concentration: > 100000 nM
Compound 4 was reported as a limit (the forecaster's own chance of this, stated with the estimate: 60%); middle value at least 1.2-fold (0.09 log units) from the limit.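

Placing 2,4-difluorobenzyl on the amide-type nitrogen in place of 2-methoxyphenyl gives an at least 3.0-fold higher number from compound 2 to compound 4 (0.49 log units; beyond the scatter), so this benzyl group does not match the activity of compound 2. The steps from compound 1 and compound 3 to compound 4 cannot be read, since both ends are limits. Compound 2 therefore remains the only compound with a value short of the limit in this assay: the limit of > 100000 nM in this assay, at which 3 of the 4 values shown sit.

As far as these compounds go, the order among compounds 1, 3 and 4 stays open. A 2-methoxybenzyl or unsubstituted phenyl group could show whether the 2-methoxyphenyl group itself carries the readable activity.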